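Swapping the branched side chain for an oxolane ring

A few compounds are considered here, and "the series" means these few. Any claim that something is new, unique, unknown or untested is made for them only; others in the source may bear on it.

Measured compounds:
- compound 1, `Nc1ccc2cccc(OCCC(F)(F)F)c2n1`: 722 nM
- compound 2, `Nc1ccc2cccc(OC3CCCCCC3)c2n1`: 137 nM
- compound 3, `CCC(C)COc1cccc2ccc(N)nc12`: 36 nM

All three share one core and differ only in the group attached through oxygen on the aromatic ring. In an assay on cells with melanin-concentrating hormone receptor 1 (Homo sapiens) as the target, read by radioligand binding (on this read-out higher numbers stand for weaker inhibition and lower numbers for stronger inhibition), compound 3 gives the lowest number of the three: compound 2 sits at 137 nM and compound 1 at 722 nM, both clearly higher.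

Compound 4, `Nc1ccc2cccc(OCC3CCCO3)c2n1`, is the next step from compound 3. The change is oxolan-2-yl in place of sec-butyl on a saturated chain carbon bound to an oxygen on an aromatic ring. Within the data shown here, the only measured step that bears on it is a 20-fold lower number from compound 1 to compound 3 (1.30 log units; beyond the scatter), which shows that this position tolerates large swings. That step went from a fluorinated chain to a plain branched chain; the present move goes the other way in character, from a plain chain to a ring that carries an oxygen. Without a measured pair of that kind, a moderate loss is expected rather than a gain, so the estimated step of a 3.1-fold higher number from compound 3 to compound 4 (0.49 log units; beyond the scatter) points toward a higher number. Compound 4 is therefore estimated at 110 nM, with a range from 35 nM to 400 nM.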

Compound 4, half-maximal inhibitory concentration: > 2000 nM
Compound 4 ended at the assay's limit; the forecaster's own chance of this, stated with the estimate: 5%; middle value at least 18-fold (1.25 log units) from the limit.
By their numbers in this assay, from the lowest: compound 3; then compound 2; then compound 1. At a limit, above all of these: compound 4.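

Compound 4 stands at a limit of this assay, not at a true number: the limit of > 2000 nM in this assay, at which 1 of the 4 values shown sits.

Even so, the limit gives an at least 55-fold higher number from compound 3 to compound 4 (1.74 log units; beyond the scatter), which shows that oxolan-2-yl in place of sec-butyl, one added heavy atom that brings a ring and a hydrogen-bond acceptor, can cost far more here than any step among the earlier compounds. With an at least 2.7-fold higher number from compound 1 to compound 4 (0.44 log units; beyond the scatter), the new group also falls behind 2,2,2-trifluoroethyl, whereas compound 2, which carries a ring without a ring oxygen, gives 137 nM, so in this one case a ring alone does not bring so large a loss.

From the compounds shown here alone, what drives the loss stays open, since the ring and its oxygen arrive together. A cyclopentylmethyl group, the same ring with carbon in place of oxygen, would separate the two, and a pyrrolidine ring would test an amine there.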